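Ethyl ester versus free acid on two related cores

The source may hold more compounds than are shown below. What is called first, only, known or untested is meant among the compounds shown, and "the series" means these compounds.

Measured so far:
compound 1 `CCOC(=O)CC(=O)N1CCSC1COc1ccccc1O` — 20 mg/kg
compound 2 `COc1ccccc1OCC1N(C(=O)CC(=O)O)CC[S+]1[O-]` — 20 mg/kg
compound 3 `O=C(O)CC(=O)N1CCSC1COc1ccccc1O` — 25 mg/kg

The series is followed in a functional assay on the whole organism for inhibition, with Cavia porcellus as the target; a lower number here means that less compound is needed, a higher number that more compound is needed for the effect. Compound 3 gives 25 mg/kg and compound 1 gives 20 mg/kg; the two share a core and differ only by ethyl in place of hydrogen on an oxygen next to a carbonyl group, which gave a 1.3-fold lower number from compound 3 to compound 1 (0.10 log units; within the scatter). Compound 2 gives 20 mg/kg. The difference between the core of compound 2 and the core of compound 3 is not broken down here.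

Compound 4 `CCOC(=O)CC(=O)N1CC[S+]([O-])C1COc1ccccc1OC` is not yet measured. It stands to compound 2 as compound 1 stands to compound 3: ethyl in place of hydrogen on an oxygen next to a carbonyl group. The place is described in the same words for both pairs, so this is the same change made on a second core.

Within the data shown here, with only one earlier instance of the change, the expectation for compound 4 rests on that step alone: because a 1.3-fold lower number from compound 3 to compound 1 (0.10 log units; within the scatter) was within the scatter, the step from compound 2 to compound 4 in this assay is expected to be a 1.2-fold lower number from compound 2 to compound 4 (0.07 log units; within the scatter). Compound 4 is therefore estimated at 17 mg/kg, with a range from 8 mg/kg to 35 mg/kg.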

Compound 4, dose for half-maximal effect: 27 mg/kg
Compound 4: middle estimate off by 1.6-fold (0.20 log units), on the low side; the measured number falls inside the stated range.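

Ethyl in place of hydrogen on an oxygen next to a carbonyl group gives, in this assay, a 1.4-fold higher number from compound 2 to compound 4 (0.13 log units; within the scatter). Set beside the earlier instance, the change does not separate between the two cores: the same change on two cores in this assay, a 1.3-fold lower number (0.10 log units; within the scatter) from compound 3 to compound 1 and a 1.4-fold higher number (0.13 log units; within the scatter) from compound 2 to compound 4, 1.7-fold (0.23 log units) apart, within the scatter of two such steps

On these two cores, then, the change carries across without a step that can be told from the scatter, and the opposite directions printed for the two steps carry no weight on their own. This does not show that ethyl and hydrogen are interchangeable at this place in general, since two pairs cannot set a rule for further cores.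

The compounds shown leave open whether another group at this place, such as methyl, a longer chain or an amide in place of the ester, would give a step beyond the scatter. They also leave open how the change reads on any other core and in any assay other than this assay.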